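Swapping the halogen pattern on a urea-linked aryl ring

The source may hold more compounds than are shown below. What is called first, only, known or untested is meant among the compounds shown, and "the series" means these compounds.

Two compounds share a core and differ only in the aryl group attached to one urea nitrogen. Compound 1 `CN(C)CCn1cnnc1-c1cc(Oc2ccc(NC(=O)Nc3ccc(Cl)c(C(F)(F)F)c3)cc2F)ccn1` carries a 4-chloro-3-(trifluoromethyl)phenyl there; in an ADME assay on WI-38 cells (Homo sapiens) for cytotoxicity, read by MTT assay, with a stated time of 72 h (a higher number here means a weaker inhibitor, a lower number a stronger inhibitor), compound 1 gives 3760 nM. Compound 2 `CN(C)CCn1cnnc1-c1cc(Oc2ccc(NC(=O)Nc3ccc(F)c(Cl)c3)cc2F)ccn1` carries a 3-chloro-4-fluorophenyl instead, and in this assay compound 2 gives 7580 nM. Going by the values given here, the only step measured so far, a 2.0-fold higher number from compound 1 to compound 2 (0.30 log units; within the scatter), lies within the scatter, so the two values cannot be told apart with confidence, and compound 2 stands alongside compound 1 rather than apart from it.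

Compound 3 `CN(C)CCn1cnnc1-c1cc(Oc2ccc(NC(=O)Nc3ccc(Cl)cc3Cl)cc2F)ccn1` is not yet measured. Relative to compound 2 the change is 2,4-dichlorophenyl in place of 3-chloro-4-fluorophenyl on an amide-type nitrogen. Among the compounds with values here, this is again a rearrangement of halogens on the same aryl ring, and the one comparable step, a 2.0-fold higher number from compound 1 to compound 2 (0.30 log units; within the scatter), stayed within the scatter. Within the data shown here, no other step bears on it. For compound 3 the expected step is therefore a 1.2-fold lower number from compound 2 to compound 3 (0.07 log units; within the scatter), no change beyond the scatter. Compound 3 is estimated at 6500 nM in this assay, with a range from 2500 nM to 16000 nM.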

Compound 3, half-maximal inhibitory concentration: 10400 nM
Estimate against measurement, compound 3: 1.6-fold (0.20 log units) below, and the stated range covers the measured number.
By their numbers in this assay, from the lowest: compounds 1, 2 and 3 (each within the scatter of the next, the first and the last beyond it).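

In this assay, placing 2,4-dichlorophenyl on the amide-type nitrogen in place of 3-chloro-4-fluorophenyl gives a 1.4-fold higher number from compound 2 to compound 3 (0.14 log units; within the scatter), so this exchange of one halogen pattern for another, with the same count of heavy atoms on each side, does not separate the two compounds. Going by these compounds alone, the new information comes from the wider comparison, a 2.8-fold higher number from compound 1 to compound 3 (0.44 log units; beyond the scatter): this is the first gap at this position that clears the scatter, although it is modest. The aryl group on this nitrogen can therefore shift the number measurably, but only between the two ends of the series, as compound 2 sits within the scatter of both compound 1 and compound 3, and no measurement here offers an explanation for that shift.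

All three aryl groups shown carry halogens, so it remains open how the number would respond to an unsubstituted phenyl or to a phenyl bearing a methoxy group or an amine. From the compounds shown here alone, it also remains open whether a larger change at this position would produce a gap well beyond the modest one seen so far.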